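Series notes: sulfonyl substituent and microsomal stability

The source may hold more compounds than are shown below. What is called first, only, known or untested is meant among the compounds shown, and "the series" means these compounds.

The shared core carries an acylsulfonamide whose sulfonyl substituent varies. Compound 1 `CC(C)OC(=O)NCCS(=O)(=O)NC(=O)c1ccc(Nc2nc(NC3(c4ccc(Cl)cc4)CC3)nc(OCC(F)(F)F)n2)cc1` gives 100% in an ADME assay on microsomes from liver (Homo sapiens) for metabolic stability, with a stated time of 10 min; on this read-out higher numbers stand for a more stable compound and lower numbers for a less stable compound. Compound 2 `CC(C)(C)OC(=O)NCCS(=O)(=O)NC(=O)c1ccc(Nc2nc(NC3(c4ccc(Cl)cc4)CC3)nc(OCC(F)(F)F)n2)cc1` gives 92%; the step of a number 8 percentage points lower from compound 1 to compound 2 (within the scatter) is within the scatter. Compound 3 `CC(C)S(=O)(=O)NC(=O)c1ccc(Nc2nc(NC3(c4ccc(Cl)cc4)CC3)nc(OCC(F)(F)F)n2)cc1` gives 100%, level with compound 1 at the digits printed and together with it the highest of the three numbers; the steps of no change at the digits printed from compound 1 to compound 3 (within the scatter) and a number 8 percentage points higher from compound 2 to compound 3 (within the scatter) are both within the scatter.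

For the measured compounds named here, compound 4 `O=C(NS(=O)(=O)c1ccc(F)cc1)c1ccc(Nc2nc(NC3(c4ccc(Cl)cc4)CC3)nc(OCC(F)(F)F)n2)cc1` is not yet measured. 4-fluorophenyl in place of isopropyl on a sulfonyl sulfur The two measured steps on the sulfonyl sulfur, from compound 1 and from compound 2 to compound 3, bear on this change and neither exceeded the scatter, so no step beyond the scatter is expected here either; a 4-fluorophenyl on this sulfur has no measured precedent in the set, which widens the range. For compound 4 the expected value in this assay is 92%, between 72% and 100%, an expected step of a number 8 percentage points lower from compound 3 to compound 4 (within the scatter).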

Compound 4, percent of the compound remaining: 100%
Compound 4: middle estimate off by 8 percentage points, on the low side; the measured number falls inside the stated range.
By their numbers in this assay, from the lowest: compounds 2, 1, 3 and 4 (each within the scatter of the next).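

Notes on the new result: the sulfonyl sulfur also accepts an aromatic substituent in this assay, since replacing isopropyl with 4-fluorophenyl, which brings one six-membered aromatic ring of carbon only, gives no change at the digits printed from compound 3 to compound 4 (within the scatter). Against the two longer chains the readings are no change at the digits printed from compound 1 to compound 4 (within the scatter) and a number 8 percentage points higher from compound 2 to compound 4 (within the scatter), so no step at this position yet lies beyond the scatter, whether the substituent is a branched alkyl, a chain or an aryl group. No measured evidence accounts for this tolerance.

Still open, from the compounds shown here alone, is how this assay responds to an amine, a carboxylic acid or a longer alkyl chain on the sulfonyl sulfur. A phenyl ring without fluorine, or with another substituent in its place, also remains to be compared with 4-fluorophenyl.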